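A few compounds are considered here, and "the series" means these few. Any claim that something is new, unique, unknown or untested is made for them only; others in the source may bear on it.

Of the compounds shown here, three built on one shared core have been measured in a functional assay on 786-0 cells (Homo sapiens) for inhibition, read by sulforhodamine B assay, with a stated time of 48 h, tested at 10 uM; a lower number here means less inhibition, a higher number more inhibition at the concentration tested (going by the name of the read-out). Compound 1 `O=Cc1ccc(-c2cn3ccnc3c(-c3ccc4ncn(C5CCCCC5)c4c3)n2)cc1` gives 46.7%, compound 2 `CCc1ccc(-c2cn3ccnc3c(-c3ccc4ncn(Cc5ccccc5)c4c3)n2)cc1` gives 38.1%, and compound 3 `Cc1cccc(-c2cn3ccnc3c(-c3ccc4ncn(Cc5ccccc5)c4c3)n2)c1` gives 21.5%, the lowest of the three, with compound 2 nearest and compound 1 furthest, both gaps beyond the scatter. Compound 4 `O=Cc1ccc(-c2cn3ccnc3c(-c3ccc4ncn(Cc5ccccc5)c4c3)n2)cc1` is not yet measured; it differs from compound 3 by 4-formylphenyl in place of 3-methylphenyl on an aromatic carbon. Among the compounds with values here, the one measured single step, a number 16.6 percentage points lower from compound 2 to compound 3 (beyond the scatter), shows that changing the aryl group on this carbon moves the read-out by a modest amount. Because compound 1 gives 46.7% with the same 4-formylphenyl, an upward step is expected, a number 18.5 percentage points higher from compound 3 to compound 4 (beyond the scatter). Compound 4 is therefore expected to give 40%, within 22% to 58%.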

Compound 4, a percentage reported as inhibition, at one concentration (the size of the read-out at that concentration, not a potency): 46.7%
Compound 4: the middle estimate sits 6.7 percentage points below what was measured, and the stated range covers the measured number.
By their numbers in this assay, from the lowest: compound 3; then compounds 2, 1 and 4 (each within the scatter of the next).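

In this assay the step from 3-methylphenyl to 4-formylphenyl is a number 25.2 percentage points higher from compound 3 to compound 4 (beyond the scatter) and stands clear of the noise, yet formyl in place of ethyl gives only a number 8.6 percentage points higher from compound 2 to compound 4 (within the scatter) and so cannot be told apart, which means this aryl position responds to some changes but not to this one. On the aromatic nitrogen, benzyl in place of cyclohexyl gives no change at the digits printed from compound 1 to compound 4 (within the scatter) and leaves the result unmoved when 4-formylphenyl is present. Nothing available explains these steps. On these data alone, whether an amine or a carboxylic acid in place of formyl would hold this level remains open. So does whether cyclohexyl and benzyl stay equivalent with 4-ethylphenyl or 3-methylphenyl on the shared core.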